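Trifluoromethylphenyl Replacing Dimethoxyphenyl on the Saturated Ring Carbon

A few compounds are considered here, and "the series" means these few. Any claim that something is new, unique, unknown or untested is made for them only; others in the source may bear on it.

In a functional assay on PC-3 cells (Homo sapiens) for antiproliferative activity, read by MTT assay, tested at 1 uM (a lower number here means a weaker effect, a higher number a stronger effect of the compound at the concentration tested), compound 1 `COc1ccc(C2OC(c3cc(OC)c(OC)c(OC)c3)=NN2C(C)=O)c(OC)c1` gives 69.5%, compound 2 `COc1cc(C2=NN(C(C)=O)C(c3ccccc3C(F)(F)F)O2)cc(OC)c1OC` gives -11%, and compound 3 `COc1ccc(OC)c(C2OC(c3cc(OC)c(OC)c(OC)c3)=NN2C(C)=O)c1` gives 37.2%, placing compound 3 second highest of the three, a number a number 32.3 percentage points lower from compound 1 to compound 3 (beyond the scatter) and a number 48.2 percentage points higher from compound 2 to compound 3 (beyond the scatter). Compound 4 `COc1cc(C2=NN(C(C)=O)C(c3ccc(C(F)(F)F)cc3)O2)cc(OC)c1OC` differs from compound 3 by 4-(trifluoromethyl)phenyl in place of 2,5-dimethoxyphenyl on a saturated ring carbon. Within the data shown here, two measured steps bear on this: a number 80.5 percentage points lower from compound 1 to compound 2 (beyond the scatter) and a number 48.2 percentage points higher from compound 2 to compound 3 (beyond the scatter), both showing that a trifluoromethylphenyl on this carbon sits far below a dimethoxyphenyl in this assay. A step downward beyond the scatter is therefore expected, though the trifluoromethyl here sits at a different position on the phenyl than in compound 2. Compound 4 is estimated at 5%, within -15% to 30%, a step of a number 32.2 percentage points lower from compound 3 to compound 4 (beyond the scatter).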

Compound 4, a percentage reported as inhibition, at one concentration (the size of the read-out at that concentration, not a potency): -11%
Compound 4: the middle estimate sits 16 percentage points above what was measured; measured number inside the range.
By their numbers in this assay, from the lowest: compounds 2 and 4 (each within the scatter of the next); then compound 3; then compound 1.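

Exchanging 2-(trifluoromethyl)phenyl for 4-(trifluoromethyl)phenyl on the saturated ring carbon gives no change at the digits printed from compound 2 to compound 4 (within the scatter), so in this assay the place of the trifluoromethyl on the phenyl makes no visible difference between these two compounds. Compound 4 also repeats the losses seen for compound 2 against the dimethoxyphenyl compounds, with a number 48.2 percentage points lower from compound 3 to compound 4 (beyond the scatter) and a number 80.5 percentage points lower from compound 1 to compound 4 (beyond the scatter). Nothing available here explains why these compounds differ. Still open, on these data alone, is how a phenyl carrying an amine or a carboxylic acid would behave on this carbon, and whether either would come closer to compound 1 or to compound 4.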